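Compound 4: cyclohexyl in place of phenyl

The source may hold more compounds than are shown below. What is called first, only, known or untested is meant among the compounds shown, and "the series" means these compounds.

In an ADME assay on Vero cells (Chlorocebus sabaeus) for cytotoxicity, read by sulforhodamine B assay, with a stated time of 72 h (on this read-out higher numbers stand for weaker inhibition and lower numbers for stronger inhibition), compound 1 (`CN1Cc2ccc(OCc3ccccc3)cc2[C@@H](O)C1`) gives only a limit of the assay (> 100000 nM). Compound 3 (`CN1Cc2ccc(OCc3ccc([N+](=O)[O-])cc3)cc2[C@@H](O)C1`) also gives only a limit (> 50000 nM). Compound 2 (`CN1Cc2ccc(OCc3ccc(-c4ccccc4)cc3)cc2[C@@H](O)C1`) gives a number (23000 nM) in this assay.

Compound 4 (`CN1Cc2ccc(OCC3CCCCC3)cc2[C@@H](O)C1`) carries cyclohexyl in place of phenyl on a saturated chain carbon bound to an oxygen on an aromatic ring. The nearest evidence is an at least 4.3-fold lower number from compound 1 to compound 2 (0.63 log units; beyond the scatter) on adding phenyl and an at least 2.1-fold higher number from compound 2 to compound 3 (0.33 log units; beyond the scatter) on exchanging phenyl for nitro, both beyond the scatter. Neither step changes this ring itself, so only a small move toward a lower number is expected (an at least 1.4-fold lower number from compound 1 to compound 4 (0.15 log units; that floor lies within the scatter)). For compound 4 the estimated value is 70000 nM (expected range 30000 nM to 150000 nM).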

Compound 4, half-maximal inhibitory concentration: 65600 nM
The estimate for compound 4 lay 1.1-fold (0.03 log units) above the measured number; the range from low to high includes it.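

Cyclohexyl in place of phenyl on a saturated chain carbon bound to an oxygen on an aromatic ring is the first change shown that replaces the ring itself, and in this assay it gives an at least 1.5-fold lower number from compound 1 to compound 4 (0.18 log units; that floor lies within the scatter). The aromatic ring is therefore not required for a measurable number at this position. Compound 1 remains a limit of the assay, so only a floor can be read: the limit of > 100000 nM in this assay, at which 1 of the 4 values shown sits.

From the compounds shown here alone, the true size of this step stays open. So does the outcome with an amine or a longer chain in place of phenyl at this position.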